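Tosylamino substitution on the benzylamide of a dihydroquinazoline

A few compounds are considered here, and "the series" means these few. Any claim that something is new, unique, unknown or untested is made for them only; others in the source may bear on it.

Compound 1, `Nc1ccc(CNC(=O)CC2c3ccccc3N=C(N3CCCCC3)N2c2ccccc2)cc1`, gives 37100 nM in a functional assay on KB cells (Homo sapiens) for inhibition, read by sulforhodamine B assay; on this read-out lower numbers stand for stronger inhibition of growth and higher numbers for weaker inhibition of growth.
Compound 2, `CCN1C(N2CCCCC2)=Nc2ccccc2C1CC(=O)NCc1ccccc1`, gives 108000 nM in this assay.
Compound 3, `COC(=O)CC1c2ccccc2N=C(NCCCCCN)N1c1ccc(-c2ccccc2)cc1`, gives 3770 nM in this assay.

Of the three compounds measured, compound 2 stands with the highest number: its value lies beyond the scatter above that of compound 1 and well beyond the scatter above that of compound 3, so it is the weakest of the set as far as growth inhibition goes.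

Compound 4, `CCN1C(N2CCCCC2)=Nc2ccccc2C1CC(=O)NCc1ccc(NS(=O)(=O)c2ccc(C)cc2)cc1`, has not yet been measured. It differs from compound 2 in one place: ((4-methylphenyl)sulfonyl)amino in place of hydrogen on an aromatic carbon. The new group sits on the benzyl ring of the amide, para to a large group, and it brings a second aromatic ring, a sulfonamide donor and two acceptors into a part of the molecule that in compound 2 carries only a plain benzyl group.

Going by the values given here, no pair of measured compounds separated by a single change is available, so the size of this step cannot be read from a precedent. Compound 1, which carries an amino group at the same position of the benzyl ring together with a different substituent on the ring nitrogen, has a lower number than compound 2, which hints that a substituent in this position is tolerated or helpful. The expectation is therefore a moderate step toward stronger inhibition, a 3.6-fold lower number from compound 2 to compound 4 (0.56 log units; beyond the scatter), but with wide uncertainty. Compound 4 is estimated at 30000 nM, in a range from 8000 nM to 120000 nM.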

Compound 4, concentration for 50% growth inhibition: 22300 nM
The estimate for compound 4 lay 1.3-fold (0.13 log units) above the measured number; measured number inside the range.
By their numbers in this assay, from the lowest: compound 3; then compounds 4 and 1 (each within the scatter of the next); then compound 2.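

Putting ((4-methylphenyl)sulfonyl)amino in place of hydrogen on an aromatic carbon, para to a large group, gives a 4.8-fold lower number from compound 2 to compound 4 (0.69 log units; beyond the scatter) in this assay. Going by these compounds alone, this is the first measured size of a single change in the set, and it shows that this position can take a group of 11 heavy atoms, including a six-membered aromatic ring, with stronger inhibition of growth rather than a loss. Nothing measured here shows which part of the entering group accounts for the step, whether the aromatic ring, the sulfonyl or the amino hydrogen.

The compounds shown leave open whether a smaller group at this position on compound 2, such as a plain amine, an acetylamino or a methanesulfonylamino group, would give a step of similar size, or whether the 4-methylphenyl ring is needed for it. They also leave open whether the same ((4-methylphenyl)sulfonyl)amino group would lower the number on a compound with a phenyl group in place of the ethyl group, or whether this step holds only with the ethyl group of compound 2.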